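Chloro to 1-methylethenyl on the fused aromatic ring

The source may hold more compounds than are shown below. What is called first, only, known or untested is meant among the compounds shown, and "the series" means these compounds.

Of the compounds shown here, two have been measured in an assay on HEK293 cells for binding affinity to 5-hydroxytryptamine receptor 7 (Homo sapiens), read by radioligand binding, tested at 1 uM; a lower number here means less inhibition, a higher number more inhibition at the concentration tested (going by the name of the read-out). Compound 1 `CN1CCCN(CCn2ccc3cccc(Br)c32)CC1` gives 18% in this assay. Compound 2 `CN1CCCN(CCn2ccc3ccc(Cl)cc32)CC1` gives 85% in this assay, which is the higher of the two numbers; compound 1 stands lower by a difference beyond the usual scatter. Among the measured compounds shown here, with only these two values, no step between single-point changes is available to rank substituent effects on the shared core.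

Compound 3 `C=C(C)c1ccc2ccn(CCN3CCCN(C)CC3)c2c1` has not yet been measured in this assay. It differs from compound 2 in one place: 1-methylethenyl in place of chloro on an aromatic carbon. The group enters on an aromatic carbon of a six-membered aromatic ring of carbon only, part of a fused or bridged system of two rings, meta to a fused ring and para to a fused ring.

Nothing measured shows how a carbon-based group at this position compares with the halogen of compound 2. The expectation is a downward step of moderate size from compound 2 to compound 3, a number 25 percentage points lower from compound 2 to compound 3 (beyond the scatter), that is likely beyond the scatter. Compound 3 is therefore expected to give about 60% in this assay, within a range from 25% to 90%.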

Compound 3, a percentage reported as inhibition, at one concentration (the size of the read-out at that concentration, not a potency): 72%
Beside the measured number, compound 3's estimate is 12 percentage points below it, within the range that was stated.
By their numbers in this assay, from the lowest: compound 1; then compound 3; then compound 2.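

In this assay this position now has its first comparison that changes one place only: a number 13 percentage points lower from compound 2 to compound 3 (beyond the scatter), with 1-methylethenyl in place of chloro. The step is modest and lies beyond the scatter, yet compound 3 still gives 72%, so on an aromatic carbon meta to a fused ring and para to a fused ring, a high read-out at the tested concentration does not depend on the chloro, and a group of 3 heavy atoms with a double bond outside aromatic rings retains most of it. Nothing measured here bears on the reason for this step.

Going by these compounds, it remains open whether the double bond matters, which an isopropyl group at this position would address, and how a methoxy group, an amine or a carboxylic acid would read there. Also open, on these data alone, is whether the same step would hold with a longer chain on the shared core, and how far a read-out at one concentration reflects potency across these compounds.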